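Removing the Ethyl Group From a Serotonin Receptor Ligand

The source may hold more compounds than are shown below. What is called first, only, known or untested is meant among the compounds shown, and "the series" means these compounds.

Compound 1, `CCC1(CCCCN2CCN(c3ccc(F)cc3)CC2)C(=O)Nc2ccc(F)cc21`, was tested in an assay on CHO cells for displacement of a labelled ligand from 5-hydroxytryptamine receptor 7 (Homo sapiens) (on this read-out lower numbers stand for stronger inhibition and higher numbers for weaker inhibition), and gave 1.5 nM. Among the three compounds measured so far it stands highest, so it shows the weakest inhibition of the three. Compound 2, `CCC1(CCCCN2CCN(c3ccc(F)cc3)CC2)C(=O)Nc2ccccc21`, gives 0.43 nM in this assay, and the change from compound 1 to compound 2, hydrogen in place of fluoro on an aromatic carbon, brings a 3.5-fold lower number from compound 1 to compound 2 (0.54 log units; beyond the scatter). Compound 3, `CCC1(CCCCN2CCN(c3ccc(F)c(Cl)c3)CC2)C(=O)Nc2ccccc21`, gives 0.6 nM in this assay, and the step of a 1.4-fold higher number from compound 2 to compound 3 (0.14 log units; within the scatter), chloro in place of hydrogen on an aromatic carbon, stays within the scatter.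

The compound not yet measured is compound 4, `O=C1Nc2ccc(F)cc2C1CCCCN1CCN(c2ccc(F)cc2)CC1`. It differs from compound 1 in a single place: hydrogen in place of ethyl on a saturated ring carbon. Both measured steps concern a halogen on an aromatic ring and leave the ethyl untouched, so neither bears directly on this change, and the data give no guide to the size or direction of removing the ethyl. A modest increase is nonetheless expected for compound 4 in this assay, as a 2.7-fold higher number from compound 1 to compound 4 (0.43 log units; beyond the scatter), with wide uncertainty. The estimate for compound 4 is 4 nM, with a range from 1 nM to 15 nM.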

Compound 4, inhibition constant: 3.4 nM
The estimate for compound 4 lay 1.2-fold (0.07 log units) above the measured number; the range from low to high includes it.
By their numbers in this assay, from the lowest: compounds 2 and 3 (each within the scatter of the next); then compound 1; then compound 4.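

Among these compounds, until this point every step had changed a halogen on an aromatic ring, while the ethyl on the saturated ring carbon stayed in place, so this is the first direct reading of that position. In this assay, hydrogen in place of ethyl gives a 2.3-fold higher number from compound 1 to compound 4 (0.36 log units; beyond the scatter), a modest step beyond the scatter, and compound 4 still gives 3.4 nM, so the ethyl is not needed for strong inhibition in this series, although losing it weakens inhibition somewhat. Nothing available explains why the step has this direction or size.

As far as these compounds go, it remains open how this carbon would respond to other groups, such as a methyl, a longer chain such as propyl or butyl, or a hydroxyl, and so whether the ethyl is a better fit here than its neighbours in size or kind. From the compounds shown here alone, it is also open whether the same removal of the ethyl would give a step of similar size in compound 2 or compound 3, which differ from compound 1 in their halogens.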